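This account rests on a few compounds, and the source may have more. Where it says the series, first, only, none or still open, it means among the compounds named here.

The study concerns a small set of compounds tested in a functional assay on HCT-116 cells (Homo sapiens) for cytotoxicity, read by MTT assay, with a stated time of 72 h; a higher number here means a weaker inhibitor, a lower number a stronger inhibitor. Compound 1 `O=C(NCc1ccc(F)cc1)c1nc(Br)c2cccnc2c1NCCCNc1c(C(=O)NCc2ccc(F)cc2)nc(Br)c2cccnc12` joins two copies of the shared core through a linker. In this assay compound 1 returns only a limit, > 20000 nM (the limit of > 20000 nM in this assay, at which 1 of the 3 values shown sits). Compound 2 `C[C@@H](CO)Nc1nc(C(=O)NCc2ccc(F)cc2)c(O)c2ncccc12` has no result in this assay, "not determined" (no result reported). Compound 3 `COC(=O)CNc1c(C(=O)NCc2ccc(F)cc2)nc(Br)c2cccnc12` is the starting point of the step followed here. In this assay compound 3 likewise gives only a limit, > 10000 nM, so among the numbers shown it stands where no potency could be resolved (the limit of > 10000 nM in this assay, at which 1 of the 3 values shown sits). Compound 4 `O=C(NCc1ccc(F)cc1)c1nc(Br)c2cccnc2c1NCc1ccc(F)cc1` differs from compound 3 in a single place: 4-fluorophenyl in place of methoxycarbonyl on a saturated chain carbon bound to a nitrogen on an aromatic ring. Among the measured compounds shown here, no measured pair in this set shows what such a change does, and both compounds with results sit at limits rather than at numbers. Compound 4 is therefore expected to show no step beyond the scatter, estimated as a step that the limit leaves unreadable from compound 3 to compound 4. Compound 4 is estimated at 15000 nM, within a range from 3000 nM to 60000 nM, and the most likely outcome is once more a limit.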

Compound 4, half-maximal inhibitory concentration: > 20000 nM
Compound 4: no number, only a limit; the forecaster's own chance of this, stated with the estimate: 70%; at least 1.3-fold (0.12 log units) between middle value and limit.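

Compound 3 returns only the limit > 10000 nM and no number. Compound 4 likewise returns only the limit > 20000 nM and no number, so no step can be read between compound 3 and compound 4. The compounds shown leave open how potent any of them is: none carries a resolved number.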